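The source may hold more compounds than are shown below. What is called first, only, known or untested is meant among the compounds shown, and "the series" means these compounds.

Measured so far in a toxicity assay (Melan-a cells) for cytotoxicity, with Mus musculus as the target, read by MTT assay, with a stated time of 48 h; on this read-out higher numbers stand for weaker inhibition and lower numbers for stronger inhibition:
Compound 1 `Cc1ncc([N+](=O)[O-])n1CCOC(=O)Nc1ccc(OCc2ccc(C(F)(F)F)cc2)cc1`: > 50000 nM
Compound 2 `Cc1ncc([N+](=O)[O-])n1CCOC(=O)Nc1ccc(OCc2ccc(F)cc2)cc1`: > 50000 nM

Both entries are limits of the assay, not numbers. Compound 2 stands at the limit of > 50000 nM in this assay, at which 2 of the 2 values shown sit. Compound 3 `Cc1ncc([N+](=O)[O-])n1CCOC(=O)Nc1ccc(OCc2ccc(F)c(F)c2)cc1` differs from compound 2 by a single change: fluoro in place of hydrogen on an aromatic carbon. Among the compounds with values here, the only measured step that bears on this is a step that the two limits leave unreadable from compound 1 to compound 2, with fluoro in place of trifluoromethyl, so it offers no size to carry over. No step beyond the scatter is therefore expected in this assay, and the assay may again report only a limit. The expected change is a number no higher from compound 2 to compound 3 (the limit leaves the size open). Compound 3 is expected at 50000 nM, with an estimated range from 20000 nM to 100000 nM.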

Compound 3, half-maximal inhibitory concentration: > 50000 nM
Compound 3: no number, only a limit (the forecaster's own chance of this, stated with the estimate: 75%); the middle value lies on the limit itself.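

Like compound 1 and compound 2, compound 3 gives only a limit of the assay, not a number, so no step among the three can be read. On these data alone, whether they differ at all, and at what concentration each would reach half-maximal inhibition, stays open.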